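One Change at the End of the Ethynyl Arm

The source may report more compounds than this note shows. Statements on the series, on what has been measured and on what is new or still open speak of the compounds shown alone.

The compounds share one core and differ only in the arm attached to a saturated ring carbon. Compound 1 `Cc1ccc(-n2nccn2)c(C(=O)N2C[C@H](/C=C/c3ccc(F)cn3)CC[C@H]2C)c1` carries a 2-(5-fluoropyridin-2-yl)ethenyl arm there, and in a functional assay on isolated protein for antagonist activity at Orexin receptor type 2 (Homo sapiens), read by FLIPR and calcium flux (on this read-out lower numbers stand for stronger inhibition and higher numbers for weaker inhibition), compound 1 gives 34 nM. Compound 2 `Cc1ccc(-n2nccn2)c(C(=O)N2C[C@H](C#Cc3ccc(F)cn3)CC[C@H]2C)c1` carries 2-(5-fluoropyridin-2-yl)ethynyl instead, and in this assay compound 2 gives 24 nM. The step of a 1.4-fold lower number from compound 1 to compound 2 (0.15 log units; within the scatter) shows that the ethynyl linker is at least as well tolerated as the ethenyl one. Compound 3 `Cc1ccc(-n2nccn2)c(C(=O)N2C[C@H](C#Cc3cc(CO)ccn3)CC[C@H]2C)c1` keeps the ethynyl linker and ends in 4-(hydroxymethyl)pyridin-2-yl; in this assay compound 3 gives "not determined" (no result reported), so among the measured compounds it stands without a number. Compound 4 `Cc1ccc(-n2nccn2)c(C(=O)N2C[C@H](C#Cc3cnccc3O)CC[C@H]2C)c1` differs from compound 3 in one place: 4-hydroxypyridin-3-yl in place of 4-(hydroxymethyl)pyridin-2-yl on a triple-bonded carbon.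

For the measured compounds named here, the only measured step, a 1.4-fold lower number from compound 1 to compound 2 (0.15 log units; within the scatter), concerns the linker and not the ring at its end, so it bears on the present change only indirectly, by showing that an ethynyl arm can sit on this core without loss. Nothing measured tells how exchanging one hydroxyl-bearing ring for another at the far end of that arm acts in this assay, and no direction beyond the scatter can be argued. Compound 4 is therefore expected to give about 40 nM in this assay, within a wide range from 8 nM to 200 nM.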

Compound 4, half-maximal inhibitory concentration: 52 nM
Compound 4: the middle estimate sits 1.3-fold (0.11 log units) below what was measured; the range from low to high includes it.
By their numbers in this assay, from the lowest: compounds 2, 1 and 4 (each within the scatter of the next, the first and the last beyond it).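

At the far end of the ethynyl arm, in this assay, 4-hydroxypyridin-3-yl in place of 5-fluoropyridin-2-yl on a triple-bonded carbon gives a 2.2-fold higher number from compound 2 to compound 4 (0.34 log units; beyond the scatter), a modest change and the only step shown in which the ring at the end of the arm varies while the linker stays the same. When the linker and the ring change together, the result is a 1.5-fold higher number from compound 1 to compound 4 (0.18 log units; within the scatter), so this hydroxyl-bearing ethynyl arm remains on a par with the fluorinated ethenyl arm, although it does not match the fluorinated ethynyl arm. No supporting measurement is available to explain either step.

The step from compound 3 to compound 4 cannot be read, so the comparison between the two hydroxyl-bearing rings remains unresolved, as does the question of whether the hydroxyl group or the different ring attachment accounts for the modest change at this position. As far as these compounds go, it also remains open how an amino group or a methoxy group would behave in place of the hydroxyl group on the pyridine ring at the end of the ethynyl arm.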